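A methyl-for-methoxy swap on a weak growth inhibitor

This account rests on a few compounds, and the source may have more. Where it says the series, first, only, none or still open, it means among the compounds named here.

Measured so far in a functional assay on A2780 cells (Homo sapiens) for antiproliferative activity, read by MTT assay, with a stated time of 48 h (a lower number here means a stronger inhibitor of growth, a higher number a weaker inhibitor of growth), for two compounds:
Compound 1 `COC(=O)N1N=C(c2ccc(OC)cc2)CC1c1cc(OC)c(OC)c(OC)c1` gives 5000 nM as a number
Compound 2 `COc1ccc(C2=NN(C(=O)OCc3ccccc3)C(c3cc(OC)c(OC)c(OC)c3)C2)cc1` gives > 10000 nM as a limit

Among the compounds with values here, compound 1 holds the only true number in this small set, so it cannot yet be ranked against a second number. Within the data shown here, the only other reading is the limit of > 10000 nM in this assay, at which 1 of the 2 values shown sits, and it belongs to compound 2, where it is a limit of the assay and not a number.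

Compound 3 `COC(=O)N1N=C(c2cccc(C)c2)CC1c1cc(OC)c(OC)c(OC)c1` has not been measured. It carries 3-methylphenyl in place of 4-methoxyphenyl on a carbon with a double bond to nitrogen and otherwise keeps the core of compound 1.

Among the measured compounds shown here, the one measured step is an at least 2.0-fold higher number from compound 1 to compound 2 (0.30 log units; that floor lies within the scatter) and it alters the methoxycarbonyl group, a different place, so it gives no direct guide to the size of this change. For the measured compounds named here, with no measured step at this place, no shift beyond the scatter in this assay is expected, and compound 3 should stay weak like compound 1. The expected change is a 1.2-fold higher number from compound 1 to compound 3 (0.08 log units; within the scatter) as an estimate only. Compound 3 is estimated at 6000 nM within an expected range of 2000 nM to 10000 nM for now.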

Compound 3, concentration for 50% growth inhibition: 600 nM
For compound 3 the middle estimate is 10-fold (1.00 log units) above the measured one; measured number below the stated range.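

In this assay, the swap on the carbon with a double bond to nitrogen gives an 8.3-fold lower number from compound 1 to compound 3 (0.92 log units; beyond the scatter), so this place responds to what it carries, which the earlier pair could not show because it differs only at the methoxycarbonyl group. Growth inhibition in this small set therefore does not depend on the 4-methoxyphenyl group, since 3-methylphenyl, which has no oxygen atom and no hydrogen-bond acceptor, gives the lower number. The compounds shown offer no measurement that explains this gain.

This single swap replaces methoxy with methyl and also changes the number in the group's name, so the compounds shown cannot separate the effect of the group itself from the effect of where it stands on the phenyl ring. From the compounds shown here alone, it also remains open whether an ethyl group, a chlorine atom or an amine on that phenyl ring would keep or extend the gain, and whether the gain would carry over to compounds with something other than the methoxycarbonyl group.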